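The source may hold more compounds than are shown below. What is called first, only, known or untested is meant among the compounds shown, and "the series" means these compounds.

Compound 1 `CC(Cc1ccc(NCc2cccc(Oc3ccccc3)c2)cc1)C(=O)O` is measured in a functional assay on CHO cells for agonist activity at Free fatty acid receptor 1 (Homo sapiens) (on this read-out higher numbers stand for an effect only at larger amounts of compound and lower numbers for an effect already at smaller amounts), where compound 1 gives 100 nM. Two further compounds share a different core. Compound 2 `Cc1nc(-c2ccc(C(F)(F)F)cc2)sc1CNc1ccc(CCC(N)=O)cc1` carries a primary amide at the end of its chain, and in this assay compound 2 gives 12.9 nM. Compound 3 `Cc1nc(-c2ccc(C(F)(F)F)cc2)sc1CNc1ccc(CCC(=O)NC(C)C)cc1` carries an isopropyl group on that amide nitrogen, and in this assay compound 3 gives 100 nM. Among these three numbers compound 1 sits level with compound 3 at the digits shown, the two of them together the highest; compound 2 is set apart by the single measured step of a 7.8-fold higher number from compound 2 to compound 3 (0.89 log units; beyond the scatter).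

Compound 4 `CN(C)C(=O)CCc1ccc(NCc2cccc(Oc3ccccc3)c2)cc1` is not yet measured. It differs from compound 1 in one place: (dimethylcarbamoyl)methyl in place of 1-carboxyethyl on a saturated chain carbon bound to an aromatic carbon. The acid of compound 1 thus becomes an amide whose nitrogen carries two methyl groups and no hydrogen. Going by the values given here, the only measured step that bears on this is the one from a bare amide nitrogen to a substituted one, a 7.8-fold higher number from compound 2 to compound 3 (0.89 log units; beyond the scatter), which moved the number upward. Among the compounds with values here, no measured pair compares an acid with an amide on the core of compound 1, so the expectation rests on that single step and on the wide range it leaves. Compound 4 is therefore expected to show a 2.5-fold higher number from compound 1 to compound 4 (0.40 log units; beyond the scatter), with an estimated value of 250 nM, likely between 60 nM and 1500 nM.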

Compound 4, half-maximal effective concentration: 174 nM
Compound 4: the middle estimate sits 1.4-fold (0.16 log units) above what was measured; the range from low to high includes it.
By their numbers in this assay, from the lowest: compound 2; then compounds 1, 3 and 4 (each within the scatter of the next).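

In this assay, placing (dimethylcarbamoyl)methyl in place of 1-carboxyethyl on a saturated chain carbon bound to an aromatic carbon gives a 1.7-fold higher number from compound 1 to compound 4 (0.24 log units; within the scatter), so on the core of compound 1 the two groups cannot be told apart on this read-out. The only earlier step, a 7.8-fold higher number from compound 2 to compound 3 (0.89 log units; beyond the scatter), concerned an amide nitrogen on a different core, whereas this is the first step shown that replaces a carboxylic acid with an amide. On the core of compound 1, then, a value in this range does not depend on the carboxylic acid or its hydrogen-bond donor, as the entering group has 0 hydrogen-bond donors. No measurement shown here accounts for this result.

From the compounds shown here alone, this single step changes the acid and the rest of the group together, so the separate contributions of the amide and the methyl branch of 1-carboxyethyl remain unknown. Also open, going by these compounds, is how a primary amide, an isopropyl amide, an amine or a longer chain ending in a dimethyl amide would read at this position on the core of compound 1.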